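A Benzyl Linker in Place of Dimethoxyphenyl on the Triazole

A few compounds are considered here, and "the series" means these few. Any claim that something is new, unique, unknown or untested is made for them only; others in the source may bear on it.

Compound 1 `COc1ccc(Nc2n[nH]c(-c3cccnc3Nc3cc(OC)cc(OC)c3)n2)cc1` — compound 1 gives 68% in a functional assay on A-431 cells (Homo sapiens), tested at 0.1 uM; a lower number here means less inhibition, a higher number more inhibition at the concentration tested (going by the name of the read-out)
Compound 2 `COc1cc(Nc2ncccc2-c2nc(Nc3ccc(OC)cc3OC)n[nH]2)cc(OC)c1` — compound 2 gives 17% in this assay
Compound 3 `COc1cc(Nc2ncccc2-c2n[nH]c(Nc3cc(Cl)cc(Cl)c3)n2)cc(OC)c1` — compound 3 gives "not determined" (no result reported) in this assay, so no number was reported for it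

Compound 2 stands lowest of the two numbers measured in this assay; its nearest neighbour, compound 1, lies far above it, beyond the scatter. The step to compound 4 `COc1ccc(CNc2n[nH]c(-c3cccnc3Nc3cc(OC)cc(OC)c3)n2)cc1` is 4-methoxybenzyl in place of 2,4-dimethoxyphenyl on a nitrogen on an aromatic ring. For the measured compounds named here, the only measured step that bears on it is a number 51 percentage points lower from compound 1 to compound 2 (beyond the scatter), which shows that removing one methoxy in this place gives a large rise. Going by the values given here, no step shows what the added methylene does. The expected step is a number 25 percentage points higher from compound 2 to compound 4 (beyond the scatter), upward, beyond the scatter. Compound 4 is therefore estimated at 42%, with a range of 15% to 70%.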

Compound 4, a percentage reported as inhibition, at one concentration (the size of the read-out at that concentration, not a potency): 22%
For compound 4 the middle estimate is 20 percentage points above the measured one, within the range that was stated.
By their numbers in this assay, from the lowest: compounds 2 and 4 (each within the scatter of the next); then compound 1.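

In this assay, the added methylene now has a reading of its own: 4-methoxybenzyl in place of 4-methoxyphenyl on a nitrogen on an aromatic ring gives a number 46 percentage points lower from compound 1 to compound 4 (beyond the scatter) and so removes most of the inhibition of compound 1. Exchanging 2,4-dimethoxyphenyl for 4-methoxybenzyl gives a number 5 percentage points higher from compound 2 to compound 4 (within the scatter) and so leaves both changes of compound 1 at a similar level. Nothing available explains either drop. Still open, from the compounds shown here alone, is whether a longer chain at this nitrogen would follow the benzyl result, and whether an amine on the ring would recover inhibition.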